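The compounds below may be only part of what the source reports. "The series", "measured", "known", "first", "only" and "open" are said of these compounds alone.

Compound 1 `COc1ccc(-c2ccc(C(O)Cc3cc(OC)c(OC)cc3[N+](=O)[O-])cc2)cc1` is tested in an ADME assay on HeLa Rh cells (Homo sapiens) for cytotoxicity, read by microscopy (on this read-out higher numbers stand for lower toxicity in this test and lower numbers for higher toxicity in this test), where compound 1 gives only a limit of the assay, > 244000 nM. Compound 2 `COc1cc(CC(O)c2ccc(-c3cccc(C#N)c3)cc2)c([N+](=O)[O-])cc1OC` gives 5200 nM in this assay, and compound 3 `COc1cc(CC(O)c2ccc(-c3cccc(F)c3)cc2)c([N+](=O)[O-])cc1OC` gives 7400 nM. The step of an at least 46-fold lower number from compound 1 to compound 2 (1.67 log units; beyond the scatter) and the step of an at least 32-fold lower number from compound 1 to compound 3 (1.51 log units; beyond the scatter) are both large. Both start from the limit of > 244000 nM in this assay, at which 1 of the 3 values shown sits, so their full size is not known. Between the two measured analogues the step of a 1.4-fold higher number from compound 2 to compound 3 (0.15 log units; within the scatter) is small. Compound 4 `COc1cc(CC(O)c2ccc(-c3ccccc3[N+](=O)[O-])cc2)c([N+](=O)[O-])cc1OC` carries the change (2-nitrophenyl in place of 4-methoxyphenyl on an aromatic carbon), on the same aromatic carbon as the two measured changes from compound 1. A lower number beyond the scatter is therefore expected for compound 4, a step of an at least 27-fold lower number from compound 1 to compound 4 (1.43 log units; beyond the scatter). For compound 4 the estimate is 9000 nM, with a range from 2000 nM to 60000 nM.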

Compound 4, half-maximal cytotoxic concentration: 9500 nM
Estimate against measurement, compound 4: 1.1-fold (0.02 log units) below; the measured number falls inside the stated range.
By their numbers in this assay, from the lowest: compounds 2, 3 and 4 (each within the scatter of the next). At a limit, above all of these: compound 1.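

With 2-nitrophenyl on this aromatic carbon, a third group in place of 4-methoxyphenyl gives a large step, an at least 25-fold lower number from compound 1 to compound 4 (1.40 log units; beyond the scatter), so the step is not confined to the 3-cyanophenyl and 3-fluorophenyl groups of compound 2 and compound 3. The steps of a 1.3-fold higher number from compound 3 to compound 4 (0.11 log units; within the scatter) and a 1.8-fold higher number from compound 2 to compound 4 (0.26 log units; within the scatter) do not separate these three replacing groups. The full size of the step from compound 1 remains unknown: the limit of > 244000 nM in this assay, at which 1 of the 4 values shown sits.

Going by these compounds, whether the methoxy group itself or its place on the ring sets compound 1 apart stays open. A 3-methoxyphenyl or a plain phenyl on this carbon would bear on that question.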